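Cyano to chloro on the anilide ring

The source may report more compounds than this note shows. Statements on the series, on what has been measured and on what is new or still open speak of the compounds shown alone.

Measured so far in a functional assay on NALM-6 cells (Homo sapiens) for cytotoxicity, read by luminescence and CellTiter-Glo, with a stated time of 3 days; a lower number here means a stronger inhibitor, a higher number a weaker inhibitor
- compound 1 `Cc1cc(C#N)ccc1NC(=O)c1ccc2cccnc2c1O` gives 230 nM
- compound 2 `N#Cc1ccc(NC(=O)c2ccc3cccnc3c2O)c(C#N)c1` gives 350 nM

Among the measured compounds shown here, compound 2 lies within the scatter of compound 1, the only other measured compound, so the two cannot be ranked. Compound 3 `N#Cc1ccc(NC(=O)c2ccc3cccnc3c2O)c(Cl)c1` is the next step from compound 2, with chloro in place of cyano on an aromatic carbon, ortho to a large group (chloro in place of cyano on an aromatic carbon). For the measured compounds named here, one measured step bears on this, a change at the same aromatic carbon (a 1.5-fold higher number from compound 1 to compound 2 (0.18 log units; within the scatter)), and it stays within the scatter. Going by the values given here, a single step is thin support, and no measurement yet shows chloro at this carbon. No shift beyond the scatter is expected in this assay, in either direction. The expected step is small (a 1.4-fold lower number from compound 2 to compound 3 (0.15 log units; within the scatter)). Compound 3 is estimated at 250 nM (expected range 110 nM to 550 nM).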

Compound 3, half-maximal inhibitory concentration: 420 nM
The estimate for compound 3 lay 1.7-fold (0.23 log units) below the measured number; the measured number falls inside the stated range.
By their numbers in this assay, from the lowest: compounds 1, 2 and 3 (each within the scatter of the next).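

Chloro joins methyl and cyano at this aromatic carbon, ortho to a large group, and the three are not separated in this assay. Chloro in place of cyano gives (a 1.2-fold higher number from compound 2 to compound 3 (0.08 log units; within the scatter)), and chloro in place of methyl gives (a 1.8-fold higher number from compound 1 to compound 3 (0.26 log units; within the scatter)), so the read-out has not yet responded to any exchange at this carbon, even with a halogen that has no hydrogen-bond acceptor count in the computed comparison. No available evidence explains this flat reading.

Going by these compounds, whether an amine, a carboxylic acid or a longer chain at this carbon would move the number beyond the scatter remains open. Also open, on these data alone, is how far the flat reading depends on the cyano group that stays in place in all three compounds.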